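Methoxy in Place of Fluoro on the Urea Aryl Ring

This account rests on a few compounds, and the source may have more. Where it says the series, first, only, none or still open, it means among the compounds named here.

Compound 1 `O=C(Nc1cccc(CNc2nccnc2Cl)c1)Nc1ccccc1F` gives 7450 nM in a functional assay on T-24 cells (Homo sapiens) for antiproliferative activity, read by MTT assay, with a stated time of 48 h; a higher number here means a weaker inhibitor, a lower number a stronger inhibitor.
Compound 2 `O=C(Nc1cccc(CNc2nccnc2Cl)c1)Nc1cccc(C(F)(F)F)c1` gives 5080 nM in this assay.
Compound 3 `Cc1cccc(NC(=O)Nc2cccc(CNc3nccnc3Cl)c2)c1` gives 9570 nM in this assay.

Among these three numbers compound 1 stands second highest. Its nearest neighbour is compound 3, with a 1.3-fold higher number from compound 1 to compound 3 (0.11 log units; within the scatter), a step within the scatter; compound 2 gives the lowest number of the three, and the gap between compound 2 and compound 1 also lies within the scatter. For the measured compounds named here, no compound can therefore be called stronger or weaker than another on this set.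

Compound 4 `COc1ccccc1NC(=O)Nc1cccc(CNc2nccnc2Cl)c1` differs from compound 1 in one place: methoxy in place of fluoro on an aromatic carbon. Going by the values given here, two measured steps bear on this change, both on the same aryl ring of the urea. The first is a 1.3-fold higher number from compound 1 to compound 3 (0.11 log units; within the scatter), which exchanges the whole 2-fluorophenyl for 3-methylphenyl and stays within the scatter. The second is a 1.9-fold higher number from compound 2 to compound 3 (0.28 log units; within the scatter), which also stays within the scatter. Among the compounds with values here, every variation so far on this ring has left the number where it was, so for compound 4 no step beyond the scatter is expected in either direction, and the estimate is a 1.1-fold higher number from compound 1 to compound 4 (0.03 log units; within the scatter). Compound 4 is expected to give 8000 nM in this assay, within a range of 3000 nM to 22000 nM.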

Compound 4, half-maximal inhibitory concentration: 10400 nM
Beside the measured number, compound 4's estimate is 1.3-fold (0.11 log units) below it, within the range that was stated.
By their numbers in this assay, from the lowest: compounds 2, 1, 3 and 4 (each within the scatter of the next, the first and the last beyond it).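

This is the first change shown that keeps the substituent at one place on the urea aryl ring and alters only the group there. In this assay, a 1.4-fold higher number from compound 1 to compound 4 (0.14 log units; within the scatter), so on this aromatic carbon, ortho to a large group, methoxy with its 2 heavy atoms and 1 hydrogen-bond acceptor cannot be told apart from fluoro. The other new step, a 1.1-fold higher number from compound 3 to compound 4 (0.04 log units; within the scatter), also stays within the scatter, so 2-methoxyphenyl and 3-methylphenyl cannot be told apart on the amide-type nitrogen either, and the four compounds offer no evidence that could explain these readings.

The compounds shown leave open whether any group at this place can move the number beyond the scatter, since fluoro and methoxy are the only two seen there, and an amine or a carboxylic acid on the same carbon might behave differently. They also leave open whether a change elsewhere in the shared core, away from the urea aryl ring, would produce a step larger than any seen here.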